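This account rests on a few compounds, and the source may have more. Where it says the series, first, only, none or still open, it means among the compounds named here.

Compound 3 `CCCN(C)C(=O)c1ccc(-c2cc(C3=CC(=O)C=CC3=O)no2)s1` stands only at a limit on the numbers shown: in a functional assay on A549 cells (Homo sapiens) for cytotoxicity, read by XTT assay, with a stated time of 72 h (on this read-out lower numbers stand for stronger inhibition and higher numbers for weaker inhibition), compound 3 gives > 30000 nM, which is a limit of the assay and not a number. Compound 1 `CN(C)C(=O)c1ccc(-c2cc(C3=CC(=O)C=CC3=O)no2)s1` gives > 30000 nM in this assay, likewise a limit. Compound 2 `CN(Cc1ccccc1)C(=O)c1ccc(-c2cc(C3=CC(=O)C=CC3=O)no2)s1` gives > 30000 nM in this assay, again a limit. The change to compound 4 `COc1ccc(CN(C)C(=O)c2ccc(-c3cc(C4=CC(=O)C=CC4=O)no3)s2)cc1` is 4-methoxyphenyl in place of ethyl on a saturated chain carbon bound to an amide-type nitrogen. Among the compounds with values here, the steps that bear on it, a step that the two limits leave unreadable from compound 1 to compound 3, a step that the two limits leave unreadable from compound 1 to compound 2 and a step that the two limits leave unreadable from compound 2 to compound 3, cannot be sized because of the limit of > 30000 nM in this assay, at which 3 of the 3 values shown sit. No step beyond the scatter in this assay is expected, and the step from compound 3 to compound 4 is estimated as a number no higher from compound 3 to compound 4 (the limit leaves the size open). Compound 4 is therefore expected at 30000 nM, between 15000 nM and 100000 nM, most likely reported once more as a limit.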

Compound 4, half-maximal inhibitory concentration: > 30000 nM
Compound 4 ended at the assay's limit; the forecaster's own chance of this, stated with the estimate: 85%; the middle value lies on the limit itself.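

Within the data shown here, no step among compound 1, compound 2, compound 3 and compound 4 can be read, because all four values stop at the same limit: the limit of > 30000 nM in this assay, at which 4 of the 4 values shown sit. The compounds shown leave open whether any group at this place changes the cytotoxicity read-out at all.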